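Replacing 1H-indol-6-yl with 4-chlorophenyl in compound 2

This account rests on a few compounds, and the source may have more. Where it says the series, first, only, none or still open, it means among the compounds named here.

Compound 1 `COc1ccc(-c2nc(C(=O)/C=C\Nc3ccc4[nH]ccc4c3)c3ccccn23)cc1`: 17400 nM
Compound 2 `O=C(/C=C\Nc1ccc2cc[nH]c2c1)c1nc(-c2ccc(C(F)(F)F)cc2)n2ccccc12`: > 30000 nM

In a functional assay on HCT-116 cells (Homo sapiens) for cytotoxicity, read by MTT assay, with a stated time of 48 h (a higher number here means a weaker inhibitor, a lower number a stronger inhibitor), compound 2 stands at > 30000 nM, which is a limit of the assay and not a number. Compound 1 gives a true reading of 17400 nM in this assay.

Compound 3 `O=C(/C=C\Nc1ccc(Cl)cc1)c1nc(-c2ccc(C(F)(F)F)cc2)n2ccccc12` carries 4-chlorophenyl in place of 1H-indol-6-yl on an amine nitrogen, the rest of compound 2 being unchanged (4-chlorophenyl in place of 1H-indol-6-yl on an amine nitrogen). Among the measured compounds shown here, no measured pair isolates this change, so the guide is thin. A modest step towards a stronger inhibitor is expected in this assay, though another result at the limit would fit equally well. The estimated step is an at least 1.5-fold lower number from compound 2 to compound 3 (0.17 log units; that floor lies within the scatter). For compound 3 the expected value is 20000 nM, with an estimated range from 7000 nM to 50000 nM.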

Compound 3, half-maximal inhibitory concentration: 11500 nM
Compound 3: middle estimate off by 1.7-fold (0.24 log units), on the high side, and the stated range covers the measured number.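

In this assay, 4-chlorophenyl in place of 1H-indol-6-yl on the amine nitrogen gives an at least 2.6-fold lower number from compound 2 to compound 3 (0.41 log units; beyond the scatter), so in this pair the group on that nitrogen alone separates a true reading from a limit. Compound 2 gives > 30000 nM, which is a limit of the assay and not a number. The step is therefore only a floor, and its full size cannot be read: the limit of > 30000 nM in this assay, at which 1 of the 3 values shown sits.

The compounds shown leave open whether the chlorine or the loss of the five-membered aromatic ring carries this step, and whether the same exchange would hold on the core of compound 1. A plain phenyl or an alkyl chain on that amine nitrogen would help to tell these readings apart.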